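Piperidinyl acetamide series: phenyl substitution at the saturated ring carbon

The source may hold more compounds than are shown below. What is called first, only, known or untested is meant among the compounds shown, and "the series" means these compounds.

Measured so far in a functional assay on HEK293 cells for agonist activity at D(4) dopamine receptor (Homo sapiens), read by FLIPR; a higher number here means that more compound is needed for the effect, a lower number that less compound is needed:
- compound 1, `Cc1cc(NC(=O)CN2CCC(c3cccc[n+]3[O-])CC2)ccc1F`: 18 nM
- compound 2, `Cc1cccc(NC(=O)CN2CCC(c3ccc(O)cc3)CC2)c1`: 70 nM
- compound 3, `N#Cc1cccc(C(=O)NCN2CCC(c3cccc[n+]3[O-])CC2)c1`: 840 nM

Among the three numbers, compound 2 stands second highest. Its nearest neighbour is compound 1, whose value is lower by a margin beyond the scatter, and furthest away is compound 3, whose value is higher by a margin well beyond the scatter. Within the data shown here, no pair of these three differs in one place only, so none of them shows the effect of a single change on its own.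

Compound 4, `Cc1cccc(NC(=O)CN2CCC(c3ccccc3C)CC2)c1`, is not yet measured. It differs from compound 2 in one place: 2-methylphenyl in place of 4-hydroxyphenyl on a saturated ring carbon

The measured compounds give no direct guide to this swap, since the group at that carbon changes together with the aryl amide in every pair. The expectation for the step from compound 2 to compound 4 is therefore a small rise, of a size that may sit within the scatter, a 1.7-fold higher number from compound 2 to compound 4 (0.23 log units; within the scatter). For compound 4 the estimated value in this assay is 120 nM, with a range from 40 nM to 400 nM.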

Compound 4, half-maximal effective concentration: 340 nM
For compound 4 the middle estimate is 2.8-fold (0.45 log units) below the measured one, and the stated range covers the measured number.
By their numbers in this assay, from the lowest: compound 1; then compound 2; then compound 4; then compound 3.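

Among these compounds, with the aryl amide held constant, the swap gives a 4.9-fold higher number from compound 2 to compound 4 (0.69 log units; beyond the scatter) in this assay, the first reading of this saturated ring carbon on its own, and it shows that the aryl group there can move the number beyond the scatter. The change takes away the hydrogen-bond donor and acceptor of 4-hydroxyphenyl while keeping the same count of heavy atoms, yet this single step cannot separate the loss of the hydroxyl from the arrival of the methyl or from the change in where the substituent stands. Nothing measured on hand explains the rise.

Plain phenyl at this carbon would split the step into those parts, and a carboxylic acid in place of the hydroxyl remains an open comparison. Also open, from the compounds shown here alone, is whether the same swap gives a similar step with the aryl amide of compound 1.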